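The source may report more compounds than this note shows. Statements on the series, on what has been measured and on what is new or still open speak of the compounds shown alone.

Of the compounds shown here, three built on one shared core have been tested in a functional assay on HCT-116 cells (Homo sapiens) for inhibition, read by sulforhodamine B assay, with a stated time of 72 h; on this read-out lower numbers stand for stronger inhibition and higher numbers for weaker inhibition. Compound 1 `O=C(/C=C/c1cn(-c2ccccc2)nc1-c1cccnc1)c1ccsc1` gives 1300 nM. Compound 2 `O=C(/C=C/c1cn(-c2ccccc2)nc1-c1cccnc1)c1cc[nH]c1` gives 7400 nM, and the step of a 5.7-fold higher number from compound 1 to compound 2 (0.76 log units; beyond the scatter) reflects a change of the ring on the carbonyl. Compound 3 `COc1cc(C(=O)/C=C/c2cn(-c3ccccc3)nc2-c2cccnc2)cc(OC)c1OC` gives 8600 nM, a number within the scatter of that of compound 2 but beyond the scatter from that of compound 1. Compound 4 `COc1ccc(C(=O)/C=C/c2cn(-c3ccccc3)nc2-c2cccnc2)cc1OC` differs from compound 3 by hydrogen in place of methoxy on an aromatic carbon. The single measured step concerns the ring on the carbonyl and does not touch a methoxy group, so nothing shown points in either direction. A step within the scatter is expected, a 1.1-fold lower number from compound 3 to compound 4 (0.03 log units; within the scatter). Compound 4 is therefore estimated at 8000 nM, with a range from 3000 nM to 20000 nM.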

Compound 4, half-maximal inhibitory concentration: 4300 nM
Compound 4: the middle estimate sits 1.9-fold (0.27 log units) above what was measured; measured number inside the range.
By their numbers in this assay, from the lowest: compound 1; then compounds 4, 2 and 3 (each within the scatter of the next).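

In this assay, replacing one methoxy group on the aromatic ring with hydrogen leaves the result within the scatter (a 2.0-fold lower number from compound 3 to compound 4 (0.30 log units; within the scatter)), so this methoxy group has no clear effect on the number. The 3,4-dimethoxyphenyl group of compound 4 also reads level with the 1H-pyrrol-3-yl group (a 1.7-fold lower number from compound 2 to compound 4 (0.24 log units; within the scatter)), whereas thiophen-3-yl stands clearly apart (a 3.3-fold higher number from compound 1 to compound 4 (0.52 log units; beyond the scatter)). No measurement available here explains these numbers. Going by these compounds, whether an amine, a carboxylic acid or a longer chain such as butoxy at this position would shift the number stays open.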